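The compounds below may be only part of what the source reports. "The series", "measured", "known", "first", "only" and "open" are said of these compounds alone.

Three compounds have been measured in a functional assay on NCI-H460 cells (Homo sapiens) for antiproliferative activity, read by CCK-8 assay, with a stated time of 72 h, tested at 2 uM; a lower number here means a weaker effect, a higher number a stronger effect of the compound at the concentration tested:

compound 1 `CCC(C)n1cnc2c(NCc3ccc(C(=O)Nc4ccccc4N)cc3)nc(Cl)nc21` gives 47.3%
compound 2 `Cc1ccc(Nc2nc(Cl)nc3c2ncn3Cc2ccc(C(=O)Nc3ccccc3N)cc2)cc1` gives 67.3%
compound 3 `CC(C)n1cnc2c(Nc3cccc(Cl)c3)nc(NCOCc3ccc(/C=C/C(=O)Nc4ccccc4N)cc3)nc21` gives 53%

Among these three numbers compound 1 sits at the low end. Its gap to compound 2 lies beyond the usual scatter of repeated measurements, so compound 2 reads as the stronger of the two in this assay. Its gap to compound 3 lies within that scatter, so compound 1 and compound 3 cannot be told apart on these numbers.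

Compound 4 `CC(C)n1cnc2c(NCc3ccc(C(=O)Nc4ccccc4N)cc3)nc(Cl)nc21` has not yet been measured. It shares the core of compound 1 and differs from it in a single place: hydrogen in place of methyl on a saturated chain carbon, two bonds along the chain from an aromatic nitrogen. Going by the values given here, no pair of measured compounds differs in exactly one place, so there is no measured step of comparable kind to lean on. Removing one carbon from a short saturated chain is a small change, and the expected step of a number 1.3 percentage points lower from compound 1 to compound 4 (within the scatter) from compound 1 is one that stays within the scatter, with no clear direction.

Compound 4 is therefore expected to give about 46% in this assay, with a likely range from 32% to 60%.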

Compound 4, a percentage reported as inhibition, at one concentration (the size of the read-out at that concentration, not a potency): 54.2%
Compound 4: middle estimate off by 8.2 percentage points, on the low side; the measured number falls inside the stated range.
By their numbers in this assay, from the lowest: compounds 1, 3 and 4 (each within the scatter of the next); then compound 2.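

Trimming sec-butyl to isopropyl, the first change at a single place to have a measured result here, gives a number 6.9 percentage points higher from compound 1 to compound 4 (within the scatter) in this assay. At this position, then, removing one chain carbon does not separate the two compounds, and this pair supports neither a gain nor a loss in the read-out. No measurement is available that could explain how the two compounds relate, so the result stands as a number alone.

On these data alone, whether a longer chain such as n-hexyl, a ring such as cyclopentyl or a hydroxyl group on the chain would move the number beyond the scatter remains open. A single pair also leaves open whether the same trimming would give a similar step on a different core.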